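Trifluoromethyl in Place of Methoxy on Compound 2

This account rests on a few compounds, and the source may have more. Where it says the series, first, only, none or still open, it means among the compounds named here.

In a functional assay on DU-145 cells (Homo sapiens) for cytotoxicity, read by MTT assay, with a stated time of 72 h (on this read-out lower numbers stand for stronger inhibition and higher numbers for weaker inhibition), compound 1 `COc1ccc(C(=O)c2cc(OC)c(OC)c(OC)c2)cc1NC(=O)/C=C/c1cc(OC)c(OC)c(OC)c1` gives 6300 nM, while compound 2 `COc1ccc(/C=C/C(=O)Nc2cc(C(=O)c3cc(OC)c(OC)c(OC)c3)ccc2OC)cc1` gives 12800 nM, the higher of the two numbers, after a 2.0-fold higher number from compound 1 to compound 2 (0.31 log units; beyond the scatter). Compound 3 `COc1ccc(C(=O)c2cc(OC)c(OC)c(OC)c2)cc1NC(=O)/C=C/c1ccc(C(F)(F)F)cc1` differs from compound 2 by trifluoromethyl in place of methoxy on an aromatic carbon. For the measured compounds named here, only that one step, which altered the same ring, is known, and none tests a trifluoromethyl, so no step bears directly on this change. Compound 3 is therefore expected to land near compound 2, with a 1.2-fold higher number from compound 2 to compound 3 (0.07 log units; within the scatter) taken as a small rise at most. The estimate for compound 3 in this assay is 15000 nM, ranging from 6000 nM to 40000 nM.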

Compound 3, half-maximal inhibitory concentration: 4300 nM
Compound 3: middle estimate off by 3.5-fold (0.54 log units), on the high side, and the stated range ends above it.
By their numbers in this assay, from the lowest: compounds 3 and 1 (each within the scatter of the next); then compound 2.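

At this aromatic carbon, para to a large group, this assay does respond to the choice of group: trifluoromethyl in place of methoxy gives a 3.0-fold lower number from compound 2 to compound 3 (0.47 log units; beyond the scatter) and, unlike the earlier step, runs toward a lower number. With 4-(trifluoromethyl)phenyl in place of 3,4,5-trimethoxyphenyl the result is a 1.5-fold lower number from compound 1 to compound 3 (0.17 log units; within the scatter) and stays within the scatter, so the two rings cannot be told apart on this read-out. Nothing available explains the difference between methoxy and trifluoromethyl here. On these data alone, whether an amine or a chlorine atom at the same carbon would behave like trifluoromethyl or like methoxy stays open, as does whether this step holds in other cell lines.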